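Swapping the aryl group on the hydroxy-bearing compound

A few compounds are considered here, and "the series" means these few. Any claim that something is new, unique, unknown or untested is made for them only; others in the source may bear on it.

Going by the values given here, in a functional assay on COLO 205 cells (Homo sapiens) for inhibition, read by sulforhodamine B assay (on this read-out lower numbers stand for stronger inhibition of growth and higher numbers for weaker inhibition of growth), compound 3 `Oc1cccc2[nH]c(-c3ccc(-c4ccc(-c5ccc(OC(F)(F)F)cc5)cc4)cc3)nc12` gives 8320 nM and holds the lowest of the three numbers so far. Compound 2 `COc1ccc(-c2ccc(-c3ccc(-c4nc5ccccc5[nH]4)cc3)cc2)cc1` gives 45200 nM in the same read-out, and compound 1 `FC(F)(F)Oc1ccc(-c2ccc(-c3ccc(-c4nc5ccccc5[nH]4)cc3)cc2)cc1` gives 100000 nM at the top of the range.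

The next compound is compound 4 `Oc1cccc2[nH]c(-c3ccc(-c4ccc(-c5cccc(Cl)c5)cc4)cc3)nc12` with the change 3-chlorophenyl in place of 4-(trifluoromethoxy)phenyl on an aromatic carbon in which 3-chlorophenyl replaces 4-(trifluoromethoxy)phenyl on an aromatic carbon. The large step of a 12-fold lower number from compound 1 to compound 3 (1.08 log units; beyond the scatter) comes with the added hydroxy, which compound 4 keeps, so it says little about this swap. The closer guide is the modest step of a 2.2-fold lower number from compound 1 to compound 2 (0.34 log units; beyond the scatter) with methyl in place of trifluoromethyl on an oxygen, made on the group that now leaves. Among the compounds with values here, no measured pair replaces the whole aryl group, and none carries chlorine, so the direction stays open.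

Only a small change is therefore expected in this assay for now. The estimate amounts to a 1.2-fold lower number from compound 3 to compound 4 (0.08 log units; within the scatter) and is expected to stay within the scatter. Compound 4 is estimated at 7000 nM with an expected range from 2500 nM to 28000 nM in this read-out.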

Compound 4, concentration for 50% growth inhibition: 8600 nM
Compound 4: the middle estimate sits 1.2-fold (0.09 log units) below what was measured, within the range that was stated.
By their numbers in this assay, from the lowest: compounds 3 and 4 (each within the scatter of the next); then compound 2; then compound 1.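

In this assay, going by these compounds alone, with the hydroxy kept, the first exchange of the whole aryl group gives a 1.0-fold higher number from compound 3 to compound 4 (0.01 log units; within the scatter), so 3-chlorophenyl and 4-(trifluoromethoxy)phenyl cannot be told apart on this aromatic carbon, para to a large group. The hydrogen-bond acceptor of the leaving group and its larger heavy-atom count are given up here with no step beyond the scatter, and the first chlorine in the series fits at this place. Nothing available accounts for the two groups reading alike.

The swap alters both the substituent and its place on the ring, so the two contributions cannot be separated. Still open, on these data alone, is whether an amine or a carboxylic acid on this ring would shift the number, and whether the same swap reads alike on the core lacking the hydroxy.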